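Aryl swap at the thiophene: nitro to para-iodo

The source may report more compounds than this note shows. Statements on the series, on what has been measured and on what is new or still open speak of the compounds shown alone.

Three measured analogues share one core and differ only in the aryl group on the five-membered ring. Compound 1 `COc1cc(C(=O)c2sc(-c3ccc(C)cc3)cc2N)cc(OC)c1OC` carries 4-methylphenyl; in a functional assay on CCRF-CEM cells (Homo sapiens) for antiproliferative activity (on this read-out higher numbers stand for weaker inhibition and lower numbers for stronger inhibition), compound 1 gives 15 nM. Compound 2 `COc1cc(C(=O)c2sc(-c3cccs3)cc2N)cc(OC)c1OC` carries thiophen-2-yl and gives 9.4 nM. Compound 3 `COc1cc(C(=O)c2sc(-c3cccc([N+](=O)[O-])c3)cc2N)cc(OC)c1OC` carries 3-nitrophenyl and gives 5.9 nM, the lowest of the three numbers. The step of a 2.5-fold lower number from compound 1 to compound 3 (0.41 log units; beyond the scatter) is the only one beyond the scatter; the steps of a 1.6-fold lower number from compound 1 to compound 2 (0.20 log units; within the scatter) and a 1.6-fold lower number from compound 2 to compound 3 (0.20 log units; within the scatter) are not.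

Compound 4 `COc1cc(C(=O)c2sc(-c3ccc(I)cc3)cc2N)cc(OC)c1OC` is the next step from compound 3: 4-iodophenyl in place of 3-nitrophenyl on an aromatic carbon. All three measured steps concern this same aryl position, and the change here is of the same kind. The aryl carrying a para group, compound 1, sits at the higher end of the range measured so far, so replacing the nitro-bearing ring with another para-substituted phenyl is expected to move the number back in that direction, by a step of a 2.0-fold higher number from compound 3 to compound 4 (0.31 log units; beyond the scatter), estimated as modest and near the scatter. Compound 4 is therefore expected to give about 12 nM, within a range of 5 nM to 30 nM.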

Compound 4, half-maximal inhibitory concentration: 150 nM
For compound 4 the middle estimate is 13-fold (1.10 log units) below the measured one; measured number outside the range, above it.
By their numbers in this assay, from the lowest: compounds 3, 2 and 1 (each within the scatter of the next, the first and the last beyond it); then compound 4.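

In this assay the aryl position next to the ring sulfur looked forgiving across the first three compounds, but 4-iodophenyl ends that picture, with a 25-fold higher number from compound 3 to compound 4 (1.41 log units; beyond the scatter) and a 16-fold higher number from compound 2 to compound 4 (1.20 log units; beyond the scatter). The exchange of iodo for methyl on the phenyl ring alone gives a 10-fold higher number from compound 1 to compound 4 (1.00 log units; beyond the scatter), so on this position the identity of the substituent, and not only its placement on the ring, sets the number. Why iodo carries such a cost cannot be told from these data, as nothing to hand bears on a cause.

Open, on these data alone, is whether a 4-bromophenyl or 4-fluorophenyl group would give a number near that of compound 1 or near that of compound 4, which would show whether the jump is tied to iodine or extends to halogens generally. Also open, as far as these compounds go, is whether 3-iodophenyl would track compound 3 or compound 4, and where a 4-aminophenyl or 4-carboxyphenyl group would fall on the same core.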